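Changing the phenyl group of compound 3

The source may report more compounds than this note shows. Statements on the series, on what has been measured and on what is new or still open speak of the compounds shown alone.

Compound 1 `C[C@H](NC(=O)C(=O)NCCC1CCCC1)C(=O)N[C@@H](CC(=O)O)C(=O)COc1c(F)c(F)cc(F)c1F`: 11 nM
Compound 2 `C[C@H](NC(=O)C(=O)NCc1cccc(F)c1)C(=O)N[C@@H](CC(=O)O)C(=O)COc1c(F)c(F)cc(F)c1F`: 106 nM
Compound 3 `Cc1ccc(CNC(=O)C(=O)N[C@@H](C)C(=O)N[C@@H](CC(=O)O)C(=O)COc2c(F)c(F)cc(F)c2F)cc1C`: > 10000 nM

In a functional assay on Jurkat cells (Homo sapiens) (on this read-out higher numbers stand for weaker inhibition and lower numbers for stronger inhibition), compound 3 stands at > 10000 nM, which is a limit of the assay and not a number. Compound 4 `C[C@H](NC(=O)C(=O)NCc1c(Cl)cccc1Cl)C(=O)N[C@@H](CC(=O)O)C(=O)COc1c(F)c(F)cc(F)c1F` differs from it on a saturated chain carbon bound to an amide-type nitrogen: 2,6-dichlorophenyl in place of 3,4-dimethylphenyl on a saturated chain carbon bound to an amide-type nitrogen. Within the data shown here, three measured steps concern this same place: a 9.6-fold higher number from compound 1 to compound 2 (0.98 log units; beyond the scatter), an at least 900-fold higher number from compound 1 to compound 3 (2.95 log units; beyond the scatter) and an at least 94-fold higher number from compound 2 to compound 3 (1.97 log units; beyond the scatter). The phenyl group here can therefore matter greatly. Compound 2, also a substituted phenyl, gives 106 nM, and the expectation leans on it. A large step toward stronger inhibition is expected, estimated as an at least 33-fold lower number from compound 3 to compound 4 (1.52 log units; beyond the scatter). For compound 4 the expected value is 300 nM, within an estimated range of 40 nM to 3000 nM.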

Compound 4, half-maximal inhibitory concentration: 110 nM
Beside the measured number, compound 4's estimate is 2.7-fold (0.44 log units) above it; low and high end bracket the measured number.
By their numbers in this assay, from the lowest: compound 1; then compounds 2 and 4 (each within the scatter of the next). At a limit, above all of these: compound 3.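

Compound 3 stands at a limit in this assay, not at a number: the limit of > 10000 nM in this assay, at which 1 of the 4 values shown sits. Even so, an at least 90-fold lower number from compound 3 to compound 4 (1.95 log units; beyond the scatter) shows that two substituents on the phenyl ring at this place do not in themselves abolish inhibition, since 2,6-dichlorophenyl keeps it where 3,4-dimethylphenyl does not. With a 1.0-fold higher number from compound 2 to compound 4 (0.02 log units; within the scatter), 2,6-dichlorophenyl and 3-fluorophenyl cannot be told apart, while a 10-fold higher number from compound 1 to compound 4 (1.00 log units; beyond the scatter) leaves all three phenyl compounds short of cyclopentylmethyl. From the compounds shown here alone, whether 3,4-dichlorophenyl would behave like compound 3 or like compound 4 stays open, as does whether a longer chain carrying the phenyl ring would approach compound 1.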